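Swapping a halogenated phenyl ring in a biphenyl amide

The source may report more compounds than this note shows. Statements on the series, on what has been measured and on what is new or still open speak of the compounds shown alone.

Of the compounds shown here, three have been tested in an assay on HEK293 cells for inhibition of N-acylethanolamine-hydrolyzing acid amidase (Rattus norvegicus), read by LC-MS, with a stated time of 30 min; on this read-out lower numbers stand for stronger inhibition and higher numbers for weaker inhibition. Compound 1 `Cc1ccccc1CCCCCCC(=O)N1CCCC1` gives 68400 nM. Compound 2 `O=C(CCCCCCc1ccccc1Cl)N1CCCC1` reaches only the limit of the assay, > 100000 nM, so no number is known for it. Compound 3 `O=C(CCc1ccc(-c2ccccc2F)cc1)N1CCCC1` gives 2800 nM, the lowest of the two numbers; the nearest number, that of compound 1, is far higher and the gap lies beyond the scatter.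

Compound 4 `O=C(CCc1ccc(-c2cccc(Cl)c2)cc1)N1CCCC1` differs from compound 3 in a single place: 3-chlorophenyl in place of 2-fluorophenyl on an aromatic carbon. Going by the values given here, only one measured step changes a substituent on an aromatic carbon: an at least 1.4-fold higher number from compound 1 to compound 2 (0.16 log units; that floor lies within the scatter), and since compound 2 sits at the limit of > 100000 nM in this assay, at which 1 of the 3 values shown sits, the real size of that step stays unknown. That step swaps a methyl for a halogen, while the step to compound 4 swaps one halogen for another and moves it to a new spot on the ring, so the guidance is thin. The expectation is therefore a step of no size beyond the scatter, leaning at most slightly toward weaker inhibition.

Compound 4 is expected to give about 3500 nM, within a range from 1200 nM to 10000 nM. The step this estimate implies, a 1.3-fold higher number from compound 3 to compound 4 (0.10 log units; within the scatter), is expected to stay within the usual scatter.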

Compound 4, half-maximal inhibitory concentration: 25400 nM
The estimate for compound 4 lay 7.3-fold (0.86 log units) below the measured number; measured number above the stated range.
By their numbers in this assay, from the lowest: compound 3; then compound 4; then compound 1. At a limit, above all of these: compound 2.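

Both groups are halogenated phenyl rings with no net charge, yet in this assay the change produces a 9.1-fold higher number from compound 3 to compound 4 (0.96 log units; beyond the scatter) and so clearly moves the read-out toward weaker inhibition. This gives the series its first substituent change on an aromatic carbon with a size that can be read, showing that inhibition responds to what this ring carries and not merely to the presence of a halogen on it. Going by these compounds alone, the only earlier step of this kind, which replaces methyl with chloro, ends in a limit for compound 2 and has no readable size: the limit of > 100000 nM in this assay, at which 1 of the 4 values shown sits.

The halogen and its place on the ring change together, so compound 3 and compound 4 cannot show which of the two accounts for the step, and 2-chlorophenyl and 3-fluorophenyl would be the groups that pull them apart. Also open, on these data alone, is how the read-out in this assay would respond to a phenyl ring carrying an amine or a carboxylic acid, or to a longer chain leading to the amide in this biphenyl series.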